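The source may report more compounds than this note shows. Statements on the series, on what has been measured and on what is new or still open speak of the compounds shown alone.

Working notes on a small set of bis(arylidene)cyclohexanone analogues tested for killing of a human leukaemia cell line.

Compound 1 `Cc1ccc(/C=C2\CCC/C(=C\c3ccccc3[N+](=O)[O-])C2=O)cc1` is the reference. In a functional assay on HL-60 cells (Homo sapiens) for cytotoxicity, with a stated time of 24 h (on this read-out lower numbers stand for higher toxicity in this test and higher numbers for lower toxicity in this test), compound 1 gives 11000 nM. Compound 2 `COc1ccc(/C=C2\CCC/C(=C\c3ccccc3[N+](=O)[O-])C2=O)cc1` carries the change methoxy in place of methyl on an aromatic carbon and in this assay compound 2 gives 26000 nM; the step of a 2.4-fold higher number from compound 1 to compound 2 (0.37 log units; beyond the scatter) is read as a modest loss of toxicity.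

Compound 3 `Cc1ccc(/C=C2\CCC/C(=C\c3ccc([N+](=O)[O-])cc3)C2=O)cc1` has the same atoms as compound 1 joined differently; the difference between the two cores is not broken down here. In this assay compound 3 gives 27000 nM, which sits within the scatter of the value of compound 2 and beyond the scatter from that of compound 1.

Compound 4 `COc1ccc(/C=C2\CCC/C(=C\c3ccc([N+](=O)[O-])cc3)C2=O)cc1` is not yet measured. It differs from compound 3 by methoxy in place of methyl on an aromatic carbon, the same change as from compound 1 to compound 2, at the same kind of place. For the measured compounds named here, the single precedent for this change is a 2.4-fold higher number from compound 1 to compound 2 (0.37 log units; beyond the scatter). On that precedent alone, for compound 4 the expected step is a 1.9-fold higher number from compound 3 to compound 4 (0.27 log units; within the scatter). Compound 4 is therefore estimated at 50000 nM, with a range of 24000 nM to 110000 nM, the wide band reflecting that one pair alone supports the expectation.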

Compound 4, half-maximal cytotoxic concentration: > 400000 nM
Compound 4 was reported as a limit (the forecaster's own chance of this, stated with the estimate: 10%); at least 8.0-fold (0.90 log units) between middle value and limit.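

In this assay the change from 4-methylphenyl to 4-methoxyphenyl does not carry over in size from one core to the other: the same change on two cores in this assay, a 2.4-fold higher number (0.37 log units; beyond the scatter) from compound 1 to compound 2 and an at least 14-fold higher number (1.17 log units; beyond the scatter) from compound 3 to compound 4, at least 6.2-fold (0.79 log units) apart, beyond the scatter of two such steps

The step of an at least 14-fold higher number from compound 3 to compound 4 (1.17 log units; beyond the scatter) rests on a limit of the assay for compound 4, so it fixes only a bound and not a size: the limit of > 400000 nM in this assay, at which 1 of the 4 values shown sits.

Both steps run towards a higher number, so the direction is shared by these two pairs while the size is not, but two pairs give no rule for any further core and do not show what sets the two steps apart.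

On these data alone, whether an amine, a carboxylic acid or a longer alkyl chain in place of methyl on the same aromatic carbon would follow the smaller step, the larger step or neither remains open. Also open, as far as these compounds go, is which feature of the difference between the two cores goes with the gap, as these four compounds do not break that difference down.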